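The source may hold more compounds than are shown below. What is called first, only, known or untested is meant among the compounds shown, and "the series" means these compounds.

In a functional assay on OVCAR-3 cells (Homo sapiens) for antiproliferative activity, read by MTT assay, with a stated time of 24 h (on this read-out higher numbers stand for weaker inhibition and lower numbers for stronger inhibition), the measured compounds gave: compound 1 `O=c1[nH]cc(S(=O)(=O)Nc2ccccc2-c2cn(-c3ccccc3)nn2)c(=O)[nH]1`, 6650 nM; compound 2 `Cc1ccccc1-n1cc(-c2ccccc2NS(=O)(=O)c2c[nH]c(=O)[nH]c2=O)nn1`, 6550 nM; compound 3 `Cc1cccc(-n2cc(-c3ccccc3NS(=O)(=O)c3c[nH]c(=O)[nH]c3=O)nn2)c1`, 3150 nM.

Compound 2 stands second highest of the three numbers. Its nearest neighbour is compound 1, with a 1.0-fold lower number from compound 1 to compound 2 (0.01 log units; within the scatter), while compound 3 lies further away, with a 2.1-fold lower number from compound 2 to compound 3 (0.32 log units; beyond the scatter).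

Compound 4 `O=c1[nH]cc(S(=O)(=O)Nc2ccccc2-c2cn(-c3ccc(F)cc3)nn2)c(=O)[nH]1` differs from compound 2 in one place: 4-fluorophenyl in place of 2-methylphenyl on an aromatic nitrogen. Going by the values given here, the step that bears most on this is the one replacing the same group, a 2.1-fold lower number from compound 2 to compound 3 (0.32 log units; beyond the scatter), a modest change; a 1.0-fold lower number from compound 1 to compound 2 (0.01 log units; within the scatter) shows that adding a methyl on that ring did nothing. Among the compounds with values here, no measured compound carries fluorine, so the change itself has no direct precedent. Compound 4 is therefore expected to stay close to compound 2, with a 1.2-fold lower number from compound 2 to compound 4 (0.08 log units; within the scatter) not beyond the scatter. The estimate for compound 4 is 5500 nM, with a range from 2500 nM to 12000 nM.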

Compound 4, half-maximal inhibitory concentration: > 20000 nM
Compound 4: no number, only a limit (the forecaster's own chance of this, stated with the estimate: 3%); middle value at least 3.6-fold (0.56 log units) from the limit.
By their numbers in this assay, from the lowest: compound 3; then compounds 2 and 1 (each within the scatter of the next). At a limit, above all of these: compound 4.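

In this assay compound 4 gives > 20000 nM, which is a limit of the assay and not a number. Substitution on this phenyl ring can therefore weaken the read-out: fluoro in place of hydrogen gives an at least 3.0-fold higher number from compound 1 to compound 4 (0.47 log units; beyond the scatter), whereas the methyl step gave a 1.0-fold lower number from compound 1 to compound 2 (0.01 log units; within the scatter). The change to 4-fluorophenyl gives an at least 3.0-fold higher number from compound 2 to compound 4 (0.48 log units; beyond the scatter) and an at least 6.3-fold higher number from compound 3 to compound 4 (0.80 log units; beyond the scatter), the first steps upward among these compounds.

As far as these compounds go, the full size of these steps stays open: the limit of > 20000 nM in this assay, at which 1 of the 4 values shown sits. A 4-methylphenyl or 4-chlorophenyl group would show whether this loss follows fluorine itself or any group at that ring place.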